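The source may hold more compounds than are shown below. What is called first, only, known or untested is meant among the compounds shown, and "the series" means these compounds.

Compound 1 `Cc1ccc(C(=O)N/N=C/c2ccccc2)c(O)c1`: in a functional assay (Mus musculus, strain BALB/C) for inhibition, read by MTT assay, with stated times of 24 h and 72 h (a lower number here means a stronger inhibitor, a higher number a weaker inhibitor), compound 1 gives 53900 nM.
Compound 2 `COc1cccc(/C=N/NC(=O)c2ccc(C)cc2O)c1`: in this assay compound 2 gives 20600 nM.
Compound 3 `Cc1ccc(C(=O)N/N=C/c2cc(Cl)ccc2O)c(O)c1`: in this assay compound 3 gives 1290 nM.

Compound 3 stands lowest of the three, its steps to compound 2 and to compound 1 both beyond the scatter. Compound 4 `Cc1ccc(C(=O)N/N=C/c2cccc(Cl)c2)c(O)c1` differs from it in one place: hydrogen in place of hydroxy on an aromatic carbon. Going by the values given here, no measured step removes a hydroxy. Among the compounds with values here, the only measured step, a 2.6-fold lower number from compound 1 to compound 2 (0.42 log units; beyond the scatter), shows a group entering a ring of this kind and lowering the number modestly, and compound 1, carrying neither chloro nor hydroxy, sits far above compound 3. Taking the hydroxy away is therefore expected to raise the number in this assay, by a step estimated at a 7.8-fold higher number from compound 3 to compound 4 (0.89 log units; beyond the scatter). Compound 4 is expected at 10000 nM, within 2500 nM to 40000 nM.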

Compound 4, half-maximal inhibitory concentration: 24400 nM
Beside the measured number, compound 4's estimate is 2.4-fold (0.39 log units) below it; measured number inside the range.
By their numbers in this assay, from the lowest: compound 3; then compounds 2 and 4 (each within the scatter of the next); then compound 1.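

Taking away the hydroxy ortho to a large group and para to a chloro group has a large effect (a 19-fold higher number from compound 3 to compound 4 (1.28 log units; beyond the scatter)), well beyond the modest effect of adding chloro to the unsubstituted ring (a 2.2-fold lower number from compound 1 to compound 4 (0.34 log units; beyond the scatter)). Chloro in place of methoxy makes no real difference (a 1.2-fold higher number from compound 2 to compound 4 (0.07 log units; within the scatter)), so these two groups cannot be told apart here. Nothing available explains the effect of the hydroxy. On these data alone, whether an amine or a carboxylic acid could replace the hydroxy remains open. So does the effect of that hydroxy without the chloro.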